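This account rests on a few compounds, and the source may have more. Where it says the series, first, only, none or still open, it means among the compounds named here.

In an ADME assay on MDBK cells (Bos taurus) for cytotoxicity, read by MTT assay (on this read-out lower numbers stand for higher toxicity in this test and higher numbers for lower toxicity in this test), compound 3 `CC1CCC(OCCCCCCN2C[C@H](O)[C@@H](O)[C@H](O)[C@H]2CO)CC1C` is known only as a limit, > 500000 nM. Compound 2 `COc1ccc(OCCCCCCN2C[C@H](O)[C@@H](O)[C@H](O)[C@H]2CO)cc1`, with a six-membered aromatic ring in the same place, also gives only a limit, > 500000 nM. Compound 1 `OC[C@@H]1[C@@H](O)[C@H](O)[C@@H](O)CN1CCCCCCOc1ccccc1C(F)(F)F` likewise gives only a limit, > 500000 nM. Together these show (the limit of > 500000 nM in this assay, at which 3 of the 3 values shown sit).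

Compound 4 `COc1ccccc1OCCCCCCN1C[C@H](O)[C@@H](O)[C@H](O)[C@H]1CO` differs from compound 3 by a group of 8 heavy atoms (7 carbon, 1 oxygen; one six-membered aromatic ring of carbon only) in place of a group of 8 heavy atoms (8 carbon; one six-membered non-aromatic ring of carbon only), on an oxygen on a saturated carbon, so a 2-methoxyphenyl enters on an oxygen on a saturated carbon. For the measured compounds named here, the one measured step of this type is a step that the two limits leave unreadable from compound 2 to compound 3, which runs from aromatic to non-aromatic and gives no size to carry over. Going by the values given here, with every measured compound at the limit, no measured step points to a rise in toxicity in this assay, and no shift beyond the scatter is expected. The expected change is a step that the limit leaves unreadable from compound 3 to compound 4, and a report of a limit again is the likely outcome. For compound 4 the estimated value is 700000 nM, with an expected range from 350000 nM to 1400000 nM.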

Compound 4, half-maximal cytotoxic concentration: > 500000 nM
Compound 4: a limit, no number; the forecaster's own chance of this, stated with the estimate: 90%; the middle value lies beyond the limit too.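

No step from compound 1, compound 2 or compound 3 to compound 4 can be read, as all four stand at one limit: the limit of > 500000 nM in this assay, at which 4 of the 4 values shown sit.

It remains open whether the groups on the oxygen differ at all in this assay, and at what concentration any of these compounds would turn toxic.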